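The source may hold more compounds than are shown below. What is called first, only, known or untested is meant among the compounds shown, and "the series" means these compounds.

Measured so far:
Compound 1 `COc1ccc(/C=C/c2cc(OC)cc(OC)c2/C=C/C(=O)c2cc3ccccc3oc2=O)cc1` gives 9170 nM in an assay on isolated protein for inhibition of Amine oxidase [flavin-containing] B (Homo sapiens), read by fluorescence, with a stated time of 15 min; on this read-out higher numbers stand for weaker inhibition and lower numbers for stronger inhibition.
Compound 2 `COc1ccc(/C=C/c2cc(OC)cc(OC)c2/C=C/C(=O)c2cc3cc(OC)ccc3oc2=O)cc1` gives > 60000 nM in this assay, which is a limit of the assay rather than a number.
Compound 3 `COc1ccc(/C=C/c2cc(OC)cc(OC)c2/C=C/C(=O)c2cc3cccc(C)c3oc2=O)cc1` gives 20000 nM in this assay.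

Among the numbers, compound 1 has the lowest, and its nearest neighbour is compound 3, with a 2.2-fold higher number from compound 1 to compound 3 (0.34 log units; beyond the scatter); the remaining value is a limit, (the limit of > 60000 nM in this assay, at which 1 of the 3 values shown sits). Compound 4 `COc1ccc(/C=C/c2cc(OC)cc(OC)c2/C=C/C(=O)c2cc3ccc(OC)cc3oc2=O)cc1` differs from compound 1 in one place: methoxy in place of hydrogen on an aromatic carbon. Among the measured compounds shown here, two measured steps bear on this change. A methoxy in place of hydrogen at another aromatic carbon of the shared core gave an at least 6.5-fold higher number from compound 1 to compound 2 (0.81 log units; beyond the scatter), and a methyl in place of hydrogen gave a 2.2-fold higher number from compound 1 to compound 3 (0.34 log units; beyond the scatter). Both additions raised the number, so a higher number, meaning weaker inhibition, is expected for compound 4 in this assay, though its size is uncertain. Compound 4 is estimated at 30000 nM, within a range from 10000 nM to 90000 nM. That estimate means a 3.3-fold higher number from compound 1 to compound 4 (0.51 log units; beyond the scatter), a step expected to lie beyond the scatter.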

Compound 4, half-maximal inhibitory concentration: 4200 nM
Compound 4: the middle estimate sits 7.1-fold (0.85 log units) above what was measured, outside the stated range (below it).
By their numbers in this assay, from the lowest: compound 4; then compound 1; then compound 3. At a limit, above all of these: compound 2.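

At this position, a methoxy in place of hydrogen gives a 2.2-fold lower number from compound 1 to compound 4 (0.34 log units; beyond the scatter) in this assay, the only change from compound 1 shown here that lowers the number, meaning stronger inhibition. The same swap on another aromatic carbon of the shared core gave an at least 6.5-fold higher number from compound 1 to compound 2 (0.81 log units; beyond the scatter), so among these compounds the direction of the methoxy change depends on where the group sits. Adding a group to this part of the core therefore does not always weaken inhibition: compound 2 and compound 3 moved that way, and compound 4 goes against them.

Methoxy is the only group shown at this position, so it remains open whether the lower number is specific to it. A hydroxy group, an amine, a carboxylic acid or a longer ether chain on the same carbon could give a quite different number.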